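Shortening a sulfur-bound chain on a shared core

A few compounds are considered here, and "the series" means these few. Any claim that something is new, unique, unknown or untested is made for them only; others in the source may bear on it.

Measured compounds:
compound 1 `[SeH]c1nc(NCc2ccccc2)c2cccnc2n1` — 6350 nM
compound 2 `CCCCCSc1nc(NCc2ccc([Se]C)cc2)c2ccccc2n1` — 14400 nM

Both compounds were tested in a functional assay on HT-29 cells (Homo sapiens) for cytotoxicity, read by MTT assay, with a stated time of 72 h; a higher number here means a weaker inhibitor of growth, a lower number a stronger inhibitor of growth. Compound 1 gives 6350 nM in this assay. Compound 2 gives 14400 nM, the higher of the two numbers; the gap to compound 1 lies beyond the usual scatter, so compound 2 is the weaker grower inhibitor of the pair. The two compounds differ in several places at once, so no single change can be read from them.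

Compound 3 `CSc1nc(NCc2ccc([Se]C)cc2)c2ccccc2n1` has not yet been measured. It differs from compound 2 in one place: hydrogen in place of butyl on a saturated chain carbon bound to a sulfur, that is, pentylsulfanyl becomes methylsulfanyl. Among the compounds with values here, no measured pair shows the effect of such a change on this core, so the direction is open. A step from compound 2 to compound 3 of a 1.2-fold lower number from compound 2 to compound 3 (0.08 log units; within the scatter) is expected, within or near the scatter. Compound 3 is therefore estimated at 12000 nM, with a range from 4000 nM to 40000 nM.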

Compound 3, concentration for 50% growth inhibition: > 100000 nM
Compound 3 gave a limit, no number (the forecaster's own chance of this, stated with the estimate: 10%); middle value at least 8.3-fold (0.92 log units) away from the limit.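

The chain bound to the sulfur matters in this assay: cutting pentylsulfanyl back to methylsulfanyl gives an at least 6.9-fold higher number from compound 2 to compound 3 (0.84 log units; beyond the scatter), a step beyond the scatter that leaves the methylsulfanyl compound the weaker inhibitor of growth. From the compounds shown here alone, compound 3 gives > 100000 nM, which is a limit of the assay and not a number, so the full size of the drop stays unknown. The size of this step therefore rests on a single limit: the limit of > 100000 nM in this assay, at which 1 of the 3 values shown sits.

The compounds shown give only two chains at this place, pentyl and methyl, so they cannot tell whether growth inhibition fades gradually or vanishes abruptly as the chain shortens. Going by these compounds, whether a propyl chain, a longer heptyl chain or a chain ending in an amine would keep or improve growth inhibition on the shared core also stays open.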